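The source may report more compounds than this note shows. Statements on the series, on what has been measured and on what is new or still open speak of the compounds shown alone.

In a functional assay on MCF7 cells (Homo sapiens) for antiproliferative activity (on this read-out lower numbers stand for stronger inhibition and higher numbers for weaker inhibition), compound 1 (`CC(C)=CCc1cc(C(=O)Nc2cc3ccc(OCC4CCCN(C)C4)c(C)c3oc2=O)ccc1O`) gives 2640 nM and compound 2 (`CC(C)=CCc1cc(C(=O)Nc2cc3ccc(OCCCN4CCCC4)c(C)c3oc2=O)ccc1O`) gives 990 nM while compound 3 (`CCCNCCCOc1ccc2cc(NC(=O)c3ccc(O)c(CC=C(C)C)c3)c(=O)oc2c1C`) gives 980 nM and so shares the low end of the three numbers with compound 2. The next compound is compound 4 (`CC(C)=CCc1cc(C(=O)Nc2cc3ccc(OCCCN(C(C)C)C(C)C)c(C)c3oc2=O)ccc1O`). It keeps the core of compound 3 and carries one change that reads diisopropylamino in place of propylamino on a saturated chain carbon, three bonds along the chain from an oxygen on an aromatic ring and leaves the rest of the molecule as it was.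

Within the data shown here, the nearest precedent is the step of a 1.0-fold lower number from compound 2 to compound 3 (0.00 log units; within the scatter) which swaps pyrrolidin-1-yl for propylamino on that same chain carbon and stays within the scatter. The steps of a 2.7-fold lower number from compound 1 to compound 2 (0.43 log units; beyond the scatter) and a 2.7-fold lower number from compound 1 to compound 3 (0.43 log units; beyond the scatter) are modest but beyond the scatter. Both start from 1-methylpiperidin-3-yl and alter more of the chain, so they bear less directly on this change. Among the measured compounds shown here, no measured compound has diisopropylamino or anything close to it, which leaves real uncertainty. The amine swap with the closest match moved nothing, so only a slight rise is expected. In this assay the expected size is a 1.2-fold higher number from compound 3 to compound 4 (0.09 log units; within the scatter) and a move beyond the scatter is not anticipated. Compound 4 is estimated at 1200 nM with 550 nM to 2700 nM as its likely range.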

Compound 4, half-maximal inhibitory concentration: 1310 nM
Estimate against measurement, compound 4: 1.1-fold (0.04 log units) below, within the range that was stated.
By their numbers in this assay, from the lowest: compounds 3, 2, 4 and 1 (each within the scatter of the next, the first and the last beyond it).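

In this assay the position three bonds along the chain from an oxygen on an aromatic ring takes a much larger amine without a clear shift: going from propylamino, with 4 heavy atoms and 1 hydrogen-bond donor, to diisopropylamino, with 7 heavy atoms and 0 donors, gives a 1.3-fold higher number from compound 3 to compound 4 (0.13 log units; within the scatter). The open-chain diisopropylamino group also matches the ring-closed pyrrolidin-1-yl group, with a 1.3-fold higher number from compound 2 to compound 4 (0.12 log units; within the scatter), so propylamino, pyrrolidin-1-yl and diisopropylamino cannot be told apart at this position on this read-out. The comparison with the 1-methylpiperidin-3-yl compound also changes: the steps from compound 1 to compounds 2 and 3 lay beyond the scatter, whereas a 2.0-fold lower number from compound 1 to compound 4 (0.30 log units; within the scatter) sits just within it, so compound 1 no longer stands clearly apart from all the open-chain side groups.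

Nothing shown explains why these amines behave so alike. As far as these compounds go, whether any amine is needed at all remains open, and a hydroxyl group or a carboxylic acid at the end of the same propyl chain would test this, as would a 2-(diisopropylamino)ethyl group on the oxygen, which has a shorter chain.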